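Methoxy Count and Antiproliferative Potency in a Thiazole Series

The source may hold more compounds than are shown below. What is called first, only, known or untested is meant among the compounds shown, and "the series" means these compounds.

Compound 1 `COc1cc(C(=O)c2sc(Nc3ccccc3)nc2N)cc(OC)c1OC` was tested in a functional assay on L1210 cells (Mus musculus) for antiproliferative activity, read by cell counting, with a stated time of 2 days (a lower number here means a stronger inhibitor, a higher number a weaker inhibitor), where compound 1 gives 18 nM. Compound 2 `COc1ccc(C(=O)c2sc(Nc3ccccc3)nc2N)cc1OC` reaches only the limit of the assay, and in this assay compound 2 gives > 10000 nM. The change between them is methoxy in place of hydrogen on an aromatic carbon, and it made the step of an at least 550-fold lower number from compound 2 to compound 1 (2.74 log units; beyond the scatter). Both compound 2 and compound 3 `Nc1nc(Nc2ccc(F)cc2)sc1C(=O)c1ccccc1` sit at the same limit, (the limit of > 10000 nM in this assay, at which 2 of the 3 values shown sit). In this assay compound 3 gives > 10000 nM, a limit rather than a number. How the core of compound 3 differs from the core of compound 2 is not broken down here.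

Compound 4 `COc1ccc(C(=O)c2sc(Nc3ccc(F)cc3)nc2N)cc1` has not yet been measured. It differs from compound 3 by methoxy in place of hydrogen on an aromatic carbon. Going by the values given here, this is the same kind of change as the one from compound 2 to compound 1, but not the same: in compound 1 the entering methoxy sits ortho to a methoxy group, meta to a large group and meta to a methoxy group, whereas in compound 4 it sits para to a large group, on a ring that carries no other methoxy group.

Because compound 2 already gives > 10000 nM with two methoxy groups on that ring, a single methoxy on compound 4 is expected to bring a step of only a step that the limit leaves unreadable from compound 3 to compound 4. Compound 4 is therefore estimated at 15000 nM, most likely reported again as a limit, with a range from 3000 nM to 60000 nM.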

Compound 4, half-maximal inhibitory concentration: > 10000 nM
Compound 4: no number, only a limit; the forecaster's own chance of this, stated with the estimate: 65%; the middle value does not contradict the limit.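

In this assay compound 4 gives > 10000 nM, a limit and not a number. Compound 3 also stands at a limit, and the change from compound 3 to compound 4 therefore cannot be read as a step: the limit of > 10000 nM in this assay, at which 3 of the 4 values shown sit.

The compounds shown leave open where the true values of compound 3 and compound 4 lie, and so whether going from phenyl to 4-methoxyphenyl changes the activity in this assay at all.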